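Chloro for methyl on the triazole-bound phenyl ring

A few compounds are considered here, and "the series" means these few. Any claim that something is new, unique, unknown or untested is made for them only; others in the source may bear on it.

Compound 3 `Cc1ccc(-n2cc(-c3cccc(NS(=O)(=O)c4c[nH]c(=O)[nH]c4=O)c3)nn2)cc1` gives 3630 nM in a functional assay on A549 cells (Homo sapiens) for antiproliferative activity, read by MTT assay, with a stated time of 24 h (on this read-out lower numbers stand for stronger inhibition and higher numbers for weaker inhibition), the highest of the three numbers, although only its gap to compound 2 lies beyond the scatter. Compound 1 `Cc1cccc(-n2cc(-c3ccccc3NS(=O)(=O)c3c[nH]c(=O)[nH]c3=O)nn2)c1` gives 1870 nM in this assay, and compound 2 `O=c1[nH]cc(S(=O)(=O)Nc2ccccc2-c2cn(-c3ccc(Cl)cc3)nn2)c(=O)[nH]1` gives 1180 nM. Compound 4 `O=c1[nH]cc(S(=O)(=O)Nc2cccc(-c3cn(-c4cccc(Cl)c4)nn3)c2)c(=O)[nH]1` carries 3-chlorophenyl in place of 4-methylphenyl on an aromatic nitrogen. Going by the values given here, the one measured step that bears on this, a 1.6-fold lower number from compound 1 to compound 2 (0.20 log units; within the scatter), also exchanged a methylphenyl for a chlorophenyl on the same ring nitrogen and stayed within the scatter. Compound 4 is therefore expected to give a number close to that of compound 3, perhaps slightly lower, with a 1.3-fold lower number from compound 3 to compound 4 (0.11 log units; within the scatter) remaining within the scatter. The estimate for compound 4 is 2800 nM, with a range from 1200 nM to 6500 nM.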

Compound 4, half-maximal inhibitory concentration: 2430 nM
The estimate for compound 4 lay 1.2-fold (0.06 log units) above the measured number; measured number inside the range.
By their numbers in this assay, from the lowest: compounds 2, 1, 4 and 3 (each within the scatter of the next, the first and the last beyond it).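

In this assay, 3-chlorophenyl in place of 4-methylphenyl on the aromatic nitrogen gives a 1.5-fold lower number from compound 3 to compound 4 (0.17 log units; within the scatter). This shows, on the core of compound 3, that an exchange which swaps methyl for chlorine and also changes the ring position stays within the scatter, as the step on the core of compound 1 did. No data here explain this tolerance.

The compounds shown leave open how the two parts of the exchange, group and ring position, act separately. They also leave open whether an amine or a carboxylic acid on this phenyl ring would give a step beyond the scatter.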